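The source may report more compounds than this note shows. Statements on the series, on what has been measured and on what is new or still open speak of the compounds shown alone.

Measured in a functional assay on HeLa cells (Homo sapiens) for cytotoxicity, read by MTT assay, with a stated time of 72 h; on this read-out lower numbers stand for stronger inhibition and higher numbers for weaker inhibition:
- Compound 1 `CC(=O)N(/N=N/c1ccc([N+](=O)[O-])cc1)c1ccc([N+](=O)[O-])cc1`: 63000 nM
- Compound 2 `CC(=O)N(/N=N/c1ccc([N+](=O)[O-])cc1Cl)c1ccc([N+](=O)[O-])cc1Cl`: 630 nM

Compound 2 gives the lower of the two numbers at 630 nM, while compound 1 gives 63000 nM, a gap beyond the scatter. Compound 3 `O=C(c1ccccc1C(F)(F)F)N(/N=N/c1ccc([N+](=O)[O-])cc1Cl)c1ccc([N+](=O)[O-])cc1Cl` is not yet measured. It departs from compound 2 by one change: 2-(trifluoromethyl)phenyl in place of methyl on a carbonyl carbon. In words, 2-(trifluoromethyl)phenyl stands in place of methyl on a carbonyl carbon. Among the measured compounds shown here, no measured pair covers a change at this place, so the data offer no direct guide to its size or direction. The expectation therefore starts from compound 2 at 630 nM. In this assay no step beyond the scatter is expected, and neither direction is firmly favoured, although the uncertainty is wide on both sides. The expected change is a 1.3-fold lower number from compound 2 to compound 3 (0.10 log units; within the scatter). For compound 3 the estimated value is 500 nM, with an expected range from 100 nM to 2500 nM.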

Compound 3, half-maximal inhibitory concentration: 10600 nM
Estimate against measurement, compound 3: 21-fold (1.33 log units) below, and the stated range ends below it.
By their numbers in this assay, from the lowest: compound 2; then compound 3; then compound 1.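

In this assay the group on the carbonyl carbon proves to be a sensitive place: 2-(trifluoromethyl)phenyl in place of methyl gives a 17-fold higher number from compound 2 to compound 3 (1.23 log units; beyond the scatter) and so moves the number upward, a direction and size that compounds 1 and 2, both with methyl there, could not show. The read-out nevertheless tolerates a group with an aromatic ring at this place, since compound 3 gives 10600 nM in this assay and remains a measurable entry in the series. No measurement at hand accounts for the size of this step.

With a single replacement at this place, the contributions of the phenyl ring and of the trifluoromethyl group cannot be separated, so an unsubstituted phenyl, or an ethyl or longer alkyl chain on the same carbonyl carbon, would be the informative comparison. Also open, going by these compounds, is whether any group at this place gives a lower number than methyl does, and whether the step would keep its size on the core of compound 1.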